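Benzylsulfonyl ester replacing hydroxyethyl ether on the shared core

A few compounds are considered here, and "the series" means these few. Any claim that something is new, unique, unknown or untested is made for them only; others in the source may bear on it.

Measured compounds:
compound 1 `COc1ccc(/C=C/C(=O)c2ccc(OC)c3c2OC(C)(C)C=C3)cc1OCCO`: 8750 nM
compound 2 `COc1ccc(/C=C/C(=O)c2ccc(OC)c3c2OC(C)(C)C=C3)cc1OCCCN(C)C`: 2920 nM
compound 3 `COc1ccc(/C=C/C(=O)c2ccc(OC)c3c2OC(C)(C)C=C3)cc1CS(C)(=O)=O`: 9240 nM

In a functional assay on K562 cells (Homo sapiens) for cytotoxicity, read by MTT assay (a lower number here means a stronger inhibitor, a higher number a weaker inhibitor), compound 1 gives 8750 nM, the second highest of the three numbers. Its nearest neighbour is compound 3, and the step of a 1.1-fold higher number from compound 1 to compound 3 (0.02 log units; within the scatter). Going by the values given here, the only step beyond the scatter is a 3.0-fold lower number from compound 1 to compound 2 (0.48 log units; beyond the scatter). Compound 4 `COc1ccc(/C=C/C(=O)c2ccc(OC)c3c2OC(C)(C)C=C3)cc1OS(=O)(=O)Cc1ccccc1` differs from compound 1 in one place: benzylsulfonyl in place of 2-hydroxyethyl on an oxygen on an aromatic ring. Among the compounds with values here, the closest precedent, a 1.1-fold higher number from compound 1 to compound 3 (0.02 log units; within the scatter), also replaces the 2-hydroxyethoxy group and moved nothing; the modest gain in a 3.0-fold lower number from compound 1 to compound 2 (0.48 log units; beyond the scatter) came with a different group. Compound 4 is therefore expected to sit near compound 1, with a 1.1-fold lower number from compound 1 to compound 4 (0.04 log units; within the scatter). Compound 4 is estimated at 8000 nM, within 3000 nM to 25000 nM.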

Compound 4, half-maximal inhibitory concentration: > 10000 nM
Compound 4: no number, only a limit; the forecaster's own chance of this, stated with the estimate: 10%; middle value at least 1.2-fold (0.09 log units) from the limit.
By their numbers in this assay, from the lowest: compound 2; then compounds 1 and 3 (each within the scatter of the next). At a limit, above all of these: compound 4.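

In this assay compound 4 gives only a limit of the assay, > 10000 nM. With benzylsulfonyl on an oxygen on an aromatic ring, the number does not come down, though the floors of an at least 1.1-fold higher number from compound 1 to compound 4 (0.05 log units; that floor lies within the scatter) and an at least 1.0-fold higher number from compound 3 to compound 4 (0.03 log units; that floor lies within the scatter) cannot say how far it rises. Only an at least 3.4-fold higher number from compound 2 to compound 4 (0.53 log units; beyond the scatter) clears the scatter, leaving 3-(dimethylamino)propyl the one group shown on this oxygen that gives a lower number.

Open, going by these compounds, is whether a morpholine or a primary amine on a propyl chain would match compound 2. Also open, on these data alone, is how far the true value of compound 4 lies past its limit.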